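One Nitrogen Substituent, Compound 3 to Compound 4

A few compounds are considered here, and "the series" means these few. Any claim that something is new, unique, unknown or untested is made for them only; others in the source may bear on it.

Compound 1 `COc1cc(OC)c(/C=C/S(=O)(=O)Nc2ccc(OC)c(N)c2)c(OC)c1` gives 5 nM in a functional assay on DU-145 cells (Homo sapiens) for cytotoxicity, read by trypan blue exclusion, with a stated time of 96 h; on this read-out higher numbers stand for weaker inhibition and lower numbers for stronger inhibition
Compound 2 `COC(=O)C(C)Nc1cc(NS(=O)(=O)/C=C/c2c(OC)cc(OC)cc2OC)ccc1OC` gives 100 nM in this assay
Compound 3 `COC(=O)C(Nc1cc(NS(=O)(=O)/C=C/c2c(OC)cc(OC)cc2OC)ccc1OC)c1ccc(Cl)cc1` gives 5000 nM in this assay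

All three share one core and differ only in what sits on a nitrogen on an aromatic ring. Compound 3 has the highest number of the three, which makes it the weakest inhibitor here.

Compound 4 `COc1cc(OC)c(/C=C/S(=O)(=O)Nc2ccc(OC)c(NC(C(=O)O)c3ccccc3)c2)c(OC)c1` carries carboxy(phenyl)methyl in place of (4-chlorophenyl)(methoxycarbonyl)methyl on that nitrogen (carboxy(phenyl)methyl in place of (4-chlorophenyl)(methoxycarbonyl)methyl on a nitrogen on an aromatic ring). For the measured compounds named here, three measured steps bear on this change. Two are large: a 20-fold higher number from compound 1 to compound 2 (1.30 log units; beyond the scatter) and a 1000-fold higher number from compound 1 to compound 3 (3.00 log units; beyond the scatter) each follow from replacing the hydrogen on the nitrogen. The closest guide is a 50-fold higher number from compound 2 to compound 3 (1.70 log units; beyond the scatter) and it comes with 4-chlorophenyl in place of methyl. Compound 4 has no chlorine, but it keeps a six-membered aromatic ring in its group, as compound 3 does at 5000 nM in this assay. Going by the values given here, no measured step shows a carboxy group in place of a methoxycarbonyl group, so the uncertainty is wide.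

In this assay a moderate move towards a lower number is therefore expected, and the estimated step is a 3.3-fold lower number from compound 3 to compound 4 (0.52 log units; beyond the scatter) in size. The estimate for compound 4 is 1500 nM with 150 nM to 10000 nM as its expected range.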

Compound 4, half-maximal inhibitory concentration: 75 nM
Compound 4: the middle estimate sits 20-fold (1.30 log units) above what was measured; the whole stated range lies above it.
By their numbers in this assay, from the lowest: compound 1; then compounds 4 and 2 (each within the scatter of the next); then compound 3.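

In this assay, a group on this nitrogen that holds a six-membered aromatic ring does not have to give a number as high as that of compound 3: moving to carboxy(phenyl)methyl gives a 67-fold lower number from compound 3 to compound 4 (1.82 log units; beyond the scatter) and shows how much the number depends on the rest of the group, not on the ring alone. This step removes the chlorine and replaces methoxycarbonyl with a carboxy group at the same time, so it cannot assign the change to either one. Carboxy(phenyl)methyl is also no match for the plain hydrogen, with a 15-fold higher number from compound 1 to compound 4 (1.18 log units; beyond the scatter) in the comparison, yet it cannot be told apart from 1-(methoxycarbonyl)ethyl, as a 1.3-fold lower number from compound 2 to compound 4 (0.12 log units; within the scatter) shows.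

A (methoxycarbonyl)(phenyl)methyl group on this nitrogen would separate the chlorine from the carboxy group, since it differs from compound 3 by the chlorine alone and from compound 4 by the ester alone. Nothing shown here offers measured grounds for explaining why any of these steps has the size it has.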